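From ethylamino to pyrrolidin-1-yl on a shared core

The source may report more compounds than this note shows. Statements on the series, on what has been measured and on what is new or still open speak of the compounds shown alone.

Measured so far in a functional assay on MCF7 cells (Homo sapiens) for cytotoxicity, read by MTT assay, with a stated time of 72 h; on this read-out lower numbers stand for stronger inhibition and higher numbers for weaker inhibition:
- compound 1 `O=c1ccc2nc(-c3ccccc3)nn(-c3ccccc3)c-2c1`: 810 nM
- compound 2 `CCNc1cc2nc(-c3ccccc3)nn(-c3ccccc3)c-2cc1=O`: 1620 nM

Among the measured compounds shown here, with only two compounds measured, compound 2 at 1620 nM cannot be told apart from compound 1 at 810 nM, since the two values lie within the usual scatter of each other. The next compound, compound 3 `O=c1cc2n(-c3ccccc3)nc(-c3ccccc3)nc-2cc1N1CCCC1`, keeps the core of compound 2 but carries pyrrolidin-1-yl in place of ethylamino on an aromatic carbon.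

For the measured compounds named here, one measured step bears on this change: a 2.0-fold higher number from compound 1 to compound 2 (0.30 log units; within the scatter), where ethylamino replaced hydrogen on an aromatic carbon. That step did not go beyond the scatter. Going by the values given here, no measured compound carries pyrrolidin-1-yl, so the data offer no guide to direction, and no shift beyond the scatter is expected in this assay. The expected change is a 1.1-fold lower number from compound 2 to compound 3 (0.03 log units; within the scatter). For compound 3 the estimated value is 1500 nM, with an expected range from 500 nM to 4500 nM.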

Compound 3, half-maximal inhibitory concentration: 360 nM
Compound 3: the middle estimate sits 4.2-fold (0.62 log units) above what was measured; the measured number lies below the stated range.
By their numbers in this assay, from the lowest: compound 3; then compounds 1 and 2 (each within the scatter of the next).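

In this assay, the group on this aromatic carbon turns out to matter: a 4.5-fold lower number from compound 2 to compound 3 (0.65 log units; beyond the scatter), where pyrrolidin-1-yl takes the place of ethylamino. Against hydrogen on the same carbon, the result is a 2.3-fold lower number from compound 1 to compound 3 (0.35 log units; beyond the scatter), so this position can hold a group and give a lower number than hydrogen does, which the ethylamino of compound 2 did not show. The change swaps an open chain with a hydrogen-bond donor for a five-membered ring without one, but nothing measured here separates these two differences or explains the step.

Still open, as far as these compounds go, is whether the lower number belongs to pyrrolidin-1-yl alone, or would also appear with an open-chain amine such as diethylamino, or with other ring amines such as piperidin-1-yl and morpholin-4-yl. It is equally unknown whether a non-nitrogen group on this carbon, such as methoxy or a longer alkyl chain, would give a number closer to that of compound 3 or to that of compound 2.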